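Lengthening the chain: from compound 1 to compound 3

The compounds below may be only part of what the source reports. "The series", "measured", "known", "first", "only" and "open" are said of these compounds alone.

Compound 1 `CCCC(C#CC(=O)OC)O/C=C/C(=O)OC` gives 270 nM in a functional assay on HBL-100 cells (Homo sapiens) for antiproliferative activity, read by sulforhodamine B assay, with a stated time of 48 h (on this read-out lower numbers stand for stronger inhibition of growth and higher numbers for weaker inhibition of growth), the lowest of the two values recorded; compound 2 `CC(C)C(C#CC(=O)OC(C)(C)C)O/C=C/C(=O)OC(C)(C)C` gives 3000 nM, a gap beyond the scatter. Among the compounds with values here, no step between measured compounds isolates a single change. Compound 3 `CCCCC(C#CC(=O)OC)O/C=C/C(=O)OC` differs from compound 1 by methyl in place of hydrogen on a saturated chain carbon, four bonds along the chain from an oxygen on an unsaturated carbon and a triple-bonded carbon. Within the data shown here, with no measured pair to set its size, the step of a 1.1-fold higher number from compound 1 to compound 3 (0.05 log units; within the scatter) is expected to be small, within the scatter, in either direction. Compound 3 is therefore estimated at 300 nM, with a range from 120 nM to 750 nM.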

Compound 3, concentration for 50% growth inhibition: 250 nM
Beside the measured number, compound 3's estimate is 1.2-fold (0.08 log units) above it, and the stated range covers the measured number.
By their numbers in this assay, from the lowest: compounds 3 and 1 (each within the scatter of the next); then compound 2.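

Within the data shown here, the step of a 1.1-fold lower number from compound 1 to compound 3 (0.03 log units; within the scatter) in this assay is the first reading of a single change, and it shows that going from propyl to butyl at this position leaves growth inhibition within the scatter. The saturated chain therefore accepts one more carbon here without a measurable cost in this assay. Nothing available accounts for why the added methyl makes so little difference. Going by these compounds, whether a longer chain or a phenyl ring at this carbon would also hold the number remains open. The separate contribution of the ester groups is open too, as compound 2 differs from compound 1 in more than one place.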